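The source may report more compounds than this note shows. Statements on the series, on what has been measured and on what is new or still open speak of the compounds shown alone.

Measured so far:
Compound 1, `O=[N+]([O-])c1ccc(-c2cn3nc(Cc4ccc(Cl)cc4)sc3n2)cc1`: 214000 nM
Compound 2, `Clc1ccc(Cc2nn3c(Br)c(-c4ccc(Cl)cc4)nc3s2)cc1`: > 250000 nM

Both compounds were tested in a functional assay on L1210 cells (Mus musculus) for cytotoxicity, with a stated time of 48 h; on this read-out higher numbers stand for weaker inhibition and lower numbers for stronger inhibition. Compound 1 gives a numerical result of 214000 nM, so for this compound an actual number is available. The result for compound 2 is a limit of the assay rather than a number, namely > 250000 nM. Of the two values shown, the value for compound 2 is the only one that sits at the limit of > 250000 nM in this assay, at which 1 of the 2 values shown sits. Compound 2 therefore stands at the upper edge of what this assay can report, with no number attached to it.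

Compound 3, with structure `Clc1ccc(Cc2nn3c(Br)c(-c4ccc(Cl)cc4Cl)nc3s2)cc1`, has not yet been measured. It differs from compound 2 in one place: chloro in place of hydrogen on an aromatic carbon. Going by the values given here, no step between two measured compounds is available, so there is nothing here from which to gauge how large an effect this change has. The expected step is a step that the limit leaves unreadable from compound 2 to compound 3, which amounts to no movement beyond the scatter. Compound 3 is accordingly estimated at 300000 nM, with a likely range from 100000 nM to 1000000 nM.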

Compound 3, half-maximal inhibitory concentration: 31000 nM
Estimate against measurement, compound 3: 9.7-fold (0.99 log units) above; the whole stated range lies above it.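

Going by these compounds alone, this is the first sign that the ring carrying the chloro group responds to a change in this assay: going from 4-chlorophenyl to 2,4-dichlorophenyl, with chloro in place of hydrogen on an aromatic carbon ortho to a large group, gives an at least 8.0-fold lower number from compound 2 to compound 3 (0.90 log units; beyond the scatter). Compound 2 gives > 250000 nM, which is a limit of the assay and not a number. The real size of the step could therefore be larger than the printed figure, because only one of its two ends is an actual number: the limit of > 250000 nM in this assay, at which 1 of the 3 values shown sits.

With a single step, the compounds shown cannot tell whether this result is particular to chloro or whether a fluoro, a methyl, a methoxy or an amine at the same position would lower the number in a similar way. As far as these compounds go, it also remains open whether the same change would have a similar effect on a compound that differs elsewhere, for example one with hydrogen in place of the bromo group on the shared core.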